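Mouse liver microsome stability: acid head-group variants

The compounds below may be only part of what the source reports. "The series", "measured", "known", "first", "only" and "open" are said of these compounds alone.

Measured so far in an ADME assay on microsomes from liver (Mus musculus) for metabolic stability, with a stated time of 10 min; on this read-out lower numbers stand for a less stable compound and higher numbers for a more stable compound:
compound 1 `C[C@]1(C(=O)O)CC[C@H](C(=O)N2CC[C@](c3ccc(C(F)(C(F)(F)F)C(F)(F)F)cc3)(S(=O)(=O)c3ccc(F)cc3)C2)CC1` — 93%
compound 2 `CO[C@]1(C(=O)N2CC[C@](c3ccc(C(F)(C(F)(F)F)C(F)(F)F)cc3)(S(=O)(=O)c3ccc(F)cc3)C2)CC[C@H](C(=O)O)CC1` — 95%
compound 3 `O=C(O)[C@H]1CC[C@](F)(C(=O)N2CC[C@](c3ccc(C(F)(C(F)(F)F)C(F)(F)F)cc3)(S(=O)(=O)c3ccc(F)cc3)C2)CC1` — "not determined" (no result reported)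

Among the measured compounds shown here, compound 1 sits lowest of the two numbers in this assay, with compound 2 as its only neighbour; the pair differ by a number 2 percentage points higher from compound 1 to compound 2 (within the scatter), so both read as highly stable and cannot be ordered. Compound 4 `O=C(O)C12CCC(C(=O)N3CC[C@](c4ccc(C(F)(C(F)(F)F)C(F)(F)F)cc4)(S(=O)(=O)c4ccc(F)cc4)C3)(CC1)OC2` is not yet measured. It differs from compound 1 by a group of 11 heavy atoms (8 carbon, 3 oxygen; one six-membered non-aromatic ring of carbon only, one six-membered non-aromatic ring with 1 hetero atom) in place of a group of 10 heavy atoms (8 carbon, 2 oxygen; one six-membered non-aromatic ring of carbon only), on a carbonyl carbon. For the measured compounds named here, the only measured step that bears on it is the exchange from compound 1 to compound 2, which also alters the acid-bearing ring and stays within the scatter. By that precedent no step beyond the scatter is expected, a number 1 percentage points lower from compound 1 to compound 4 (within the scatter). Compound 4 is therefore estimated at 92%, with a range from 80% to 99%.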

Compound 4, percent of the compound remaining: 94%
Compound 4: the middle estimate sits 2 percentage points below what was measured; the measured number falls inside the stated range.
By their numbers in this assay, from the lowest: compounds 1, 4 and 2 (each within the scatter of the next).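

At the carbonyl carbon whose other neighbour is the amide-type nitrogen in a ring, a group with a second six-membered non-aromatic ring, one with 1 hetero atom, leaves this assay unmoved: a number 1 percentage points higher from compound 1 to compound 4 (within the scatter) and a number 1 percentage points lower from compound 2 to compound 4 (within the scatter). The bridged group therefore joins the methoxy exchange in producing no readable step, and compound 1, compound 2 and compound 4 cannot be ordered. Nothing measured gives a reason for this flat result.

Whether a group carrying an amine in place of the carboxylic acid would stay within the scatter of these compounds remains open.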